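Sulfonate in place of ester on the series' aromatic oxygen

The source may report more compounds than this note shows. Statements on the series, on what has been measured and on what is new or still open speak of the compounds shown alone.

Values in a functional assay on K562 cells (Homo sapiens) for cytotoxicity, read by MTT assay; a higher number here means a weaker inhibitor, a lower number a stronger inhibitor:
- compound 1 `COc1ccc(/C=C/C(=O)c2ccc(OC)c3c2OC(C)(C)C=C3)cc1O`: 630 nM
- compound 2 `COc1ccc(/C=C/C(=O)c2ccc(OC)c3c2OC(C)(C)C=C3)cc1OCCO`: 8750 nM
- compound 3 `COc1cccc(C(=O)Oc2cc(/C=C/C(=O)c3ccc(OC)c4c3OC(C)(C)C=C4)ccc2OC)c1`: 790 nM
- compound 4 `COc1ccc(/C=C/C(=O)c2ccc(OC)c3c2OC(C)(C)C=C3)cc1OS(=O)(=O)Cc1ccccc1`: not yet measured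

Compound 3, at 790 nM, sits with compound 1 and well apart from compound 2. The measured steps show a 1.3-fold higher number from compound 1 to compound 3 (0.10 log units; within the scatter) and an 11-fold lower number from compound 2 to compound 3 (1.04 log units; beyond the scatter).

The next change is one group on an oxygen on an aromatic ring: benzylsulfonyl in place of (3-methoxyphenyl)carbonyl on an oxygen on an aromatic ring. In words, benzylsulfonyl stands in place of (3-methoxyphenyl)carbonyl.

Among the measured compounds shown here, two measured steps bear on this place. Adding (3-methoxyphenyl)carbonyl gave a 1.3-fold higher number from compound 1 to compound 3 (0.10 log units; within the scatter), while adding 2-hydroxyethyl gave a 14-fold higher number from compound 1 to compound 2 (1.14 log units; beyond the scatter). The same oxygen can therefore carry a large group without a step beyond the scatter, but it has also produced a large step. The leaving and entering groups match in heavy atoms, aromatic ring, donors and acceptors. For the measured compounds named here, no measured compound carries a sulfonyl group, so the expectation remains loose.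

An estimated 1.2-fold higher number from compound 3 to compound 4 (0.08 log units; within the scatter) is expected in this assay, which means no step beyond the scatter, with any drift more likely towards a higher number. For compound 4 the expected value is 950 nM, with an estimated range of 300 nM to 3000 nM.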

Compound 4, half-maximal inhibitory concentration: > 10000 nM
Compound 4: only a limit was reported; the forecaster's own chance of this, stated with the estimate: 3%; middle value at least 10-fold (1.02 log units) away from the limit.
By their numbers in this assay, from the lowest: compounds 1 and 3 (each within the scatter of the next); then compound 2. At a limit, above all of these: compound 4.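

In this assay compound 4 is reported only as a limit: the limit of > 10000 nM in this assay, at which 1 of the 4 values shown sits. Exchanging (3-methoxyphenyl)carbonyl for benzylsulfonyl gives an at least 12-fold higher number from compound 3 to compound 4 (1.10 log units; beyond the scatter), and measured against the hydrogen on the same oxygen the change gives an at least 15-fold higher number from compound 1 to compound 4 (1.20 log units; beyond the scatter), so this oxygen accepts one large group but not another, even though the two groups match in heavy atoms, aromatic ring, donors and acceptors. Against the 2-hydroxyethyl group the reading is only an at least 1.1-fold higher number from compound 2 to compound 4 (0.05 log units; that floor lies within the scatter), so that floor does not settle whether benzylsulfonyl is any worse than 2-hydroxyethyl here.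

The shown compounds cannot say whether the large steps follow the sulfonyl link, the benzyl group or the missing methoxy group, and the true value of compound 4 remains unknown. A phenylacetyl ester, a 3-methoxyphenylsulfonyl group and a small methylsulfonyl group on this oxygen would pull these parts of the change apart, while a 2-aminoethyl chain would extend the comparison with 2-hydroxyethyl.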